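Thiophene for furan on the dihydropyrimidinone core

This account rests on a few compounds, and the source may have more. Where it says the series, first, only, none or still open, it means among the compounds named here.

Compound 1, `CCCOC(=O)C1=C(C)NC(=O)NC1c1cccs1`: 43%
Compound 2, `CCCC(=O)C1=C(C)NC(=O)NC1c1ccoc1`: 1%

Of the compounds shown here, two have been measured in an assay on membranes from CHO cells for displacement of a labelled ligand from adenosine receptor A1 (Homo sapiens), read by scintillation counting, with a stated time of 60 min, tested at 1 uM; a lower number here means less inhibition, a higher number more inhibition at the concentration tested (going by the name of the read-out). For the measured compounds named here, compound 1 gives 43%, while compound 2, which differs from it in two places, gives 1%, the lower of the two numbers; the gap between them lies beyond the usual scatter of this assay, though no single-point step connects the pair. Compound 3, `CCCC(=O)C1=C(C)NC(=O)NC1c1cccs1`, has not yet been measured. It keeps the propylcarbonyl group of compound 2 and differs from it in one place: thiophen-2-yl in place of furan-3-yl on a saturated ring carbon. Since compound 1, which carries the same thiophen-2-yl group, gives 43%, a rise in this assay is expected for compound 3, but compound 1 also carries a different group on its core, so the step is expected to be modest and uncertain: a number 17 percentage points higher from compound 2 to compound 3 (beyond the scatter). Compound 3 is expected to give 18%, within 2% to 45%.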

Compound 3, a percentage reported as inhibition, at one concentration (the size of the read-out at that concentration, not a potency): 2%
The estimate for compound 3 lay 16 percentage points above the measured number; measured number inside the range.
By their numbers in this assay, from the lowest: compounds 2 and 3 (each within the scatter of the next); then compound 1.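

In this assay, thiophen-2-yl in place of furan-3-yl on a saturated ring carbon gives a number 1 percentage points higher from compound 2 to compound 3 (within the scatter), so with the propylcarbonyl group in place, this exchange of rings leaves no readable change. The change on the carbonyl carbon, propyl in place of propoxy, gives a number 41 percentage points lower from compound 1 to compound 3 (beyond the scatter) and shows, with thiophen-2-yl held constant, that this one place alone carries a large step. Nothing measured bears on why that step is so large.

With the numbers of compound 2 and compound 3 both so low, the compounds shown leave open whether furan-3-yl and thiophen-2-yl would also match with propoxy on the carbonyl carbon. They also leave open whether an ethoxy group, a butoxy group or an amine at that carbon would keep the number of compound 1.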